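A few compounds are considered here, and "the series" means these few. Any claim that something is new, unique, unknown or untested is made for them only; others in the source may bear on it.

Measured so far:
- compound 1 `CCOC(=O)c1cc(-c2ccccc2)nn1CC(O)COc1ccccc1[N+](=O)[O-]`: 30000 nM
- compound 2 `CCOC(=O)c1cc(-c2ccc(Cl)cc2)nn1CC(O)COc1ccc(Cl)cc1`: 33000 nM
- compound 3 `CCOC(=O)c1cc(-c2ccc(Cl)cc2)nn1CC(O)COc1ccc([N+](=O)[O-])cc1`: 45000 nM

In a functional assay on A549 cells (Homo sapiens) for inhibition, read by MTT assay, with a stated time of 48 h (a lower number here means a stronger inhibitor, a higher number a weaker inhibitor), compound 3 gives 45000 nM, the largest of the three numbers, but its distances to compound 2 and to compound 1 both stay within the scatter, so the three measured compounds cannot be told apart on these data.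

Compound 4 `CCOC(=O)c1cc(-c2ccc(Cl)cc2)nn1CC(O)COc1ccccc1[N+](=O)[O-]` differs from compound 3 by 2-nitrophenyl in place of 4-nitrophenyl on an oxygen on a saturated carbon. Among the measured compounds shown here, no measured step bears directly on this change: the one measured step, a 1.4-fold higher number from compound 2 to compound 3 (0.13 log units; within the scatter), swaps a different group at the same place and stays within the scatter, and compound 1, which carries the same 2-nitrophenyl group as compound 4 but differs from it elsewhere, gives a number close to that of compound 3. The account therefore expects no step beyond the scatter for a 1.2-fold lower number from compound 3 to compound 4 (0.07 log units; within the scatter) in this assay. Compound 4 is estimated at 38000 nM, within a range from 18000 nM to 80000 nM.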

Compound 4, half-maximal inhibitory concentration: 26000 nM
Compound 4: middle estimate off by 1.5-fold (0.16 log units), on the high side, within the range that was stated.
By their numbers in this assay, from the lowest: compounds 4, 1, 2 and 3 (each within the scatter of the next).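

In this assay, the change from 4-nitrophenyl to 2-nitrophenyl on an oxygen on a saturated carbon gives a 1.7-fold lower number from compound 3 to compound 4 (0.24 log units; within the scatter) and so shows no readable effect of where the nitro group sits on this ring. The 2-nitrophenyl group also cannot be told apart from 4-chlorophenyl at this place, with a 1.3-fold lower number from compound 2 to compound 4 (0.10 log units; within the scatter) on that swap, while chloro in place of hydrogen on an aromatic carbon, a change elsewhere in the molecule, gives a 1.2-fold lower number from compound 1 to compound 4 (0.06 log units; within the scatter) and likewise stays within the scatter. No measurement offered here gives a reason for these numbers.

As far as these compounds go, the groups on the oxygen in these four compounds carry only chloro or nitro, so it remains open whether an amine or a carboxylic acid on that ring would shift the number beyond the scatter. The same question stands for a carboxylic acid in place of the ethyl ester, which all four compounds share.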